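Anilide series: bromophenyl to fluorophenyl on the amide nitrogen

The source may report more compounds than this note shows. Statements on the series, on what has been measured and on what is new or still open speak of the compounds shown alone.

Three compounds share the trifluoro-dihydroxy-propanoylamino heptanamide chain and differ only in the aryl group on the amide nitrogen. In a functional assay on HCT-116 cells (Homo sapiens) for inhibition, read by colorimetric assay, with a stated time of 3 days (on this read-out lower numbers stand for stronger inhibition and higher numbers for weaker inhibition), compound 1 `O=C(CCCCCCNC(=O)C(O)(O)C(F)(F)F)Nc1nc2ccc(Br)cc2o1` gives 12100 nM and compound 3 `O=C(CCCCCCNC(=O)C(O)(O)C(F)(F)F)Nc1nc2ccc(Br)cc2s1` gives 10300 nM. Compound 2 `O=C(CCCCCCNC(=O)C(O)(O)C(F)(F)F)Nc1cccc(Br)c1` gives 3060 nM in this assay, the lowest of the three numbers; the gaps to compound 3 and to compound 1 both lie beyond the scatter, so compound 2 is the most potent of the measured set.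

Compound 4 `O=C(CCCCCCNC(=O)C(O)(O)C(F)(F)F)Nc1ccc(F)cc1` is not yet measured. It differs from compound 2 by 4-fluorophenyl in place of 3-bromophenyl on an amide-type nitrogen. Within the data shown here, no pair of measured compounds shows this change, so its effect has to be guessed from the weight of the aryl group alone. A modest loss is expected, with the step from compound 2 to compound 4 estimated as a 1.8-fold higher number from compound 2 to compound 4 (0.25 log units; within the scatter) in this assay, close to the edge of the scatter. On that basis compound 4 is expected to give about 5500 nM in this assay, with a likely range from 1800 nM to 17000 nM.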

Compound 4, half-maximal inhibitory concentration: 7570 nM
Compound 4: the middle estimate sits 1.4-fold (0.14 log units) below what was measured; low and high end bracket the measured number.
By their numbers in this assay, from the lowest: compound 2; then compounds 4, 3 and 1 (each within the scatter of the next).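

Replacing 3-bromophenyl with 4-fluorophenyl on the amide-type nitrogen gives a 2.5-fold higher number from compound 2 to compound 4 (0.39 log units; beyond the scatter) in this assay, so this position responds to a change within the phenyl anilides even though both groups have the same heavy-atom count. Compound 2 remains the lowest number of the four, with its gap to each of the others beyond the scatter. Nothing available explains this step.

The halogen and its place on the ring change together in this single step, so the contribution of each cannot be separated. Also open, as far as these compounds go, is how an unsubstituted phenyl, or a phenyl carrying a nitrile, a methoxy group or a carboxylic acid, would behave at this nitrogen, and whether the same step would hold with a longer chain.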